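A few compounds are considered here, and "the series" means these few. Any claim that something is new, unique, unknown or untested is made for them only; others in the source may bear on it.

Three compounds built on one shared core were tested in an ADME assay on BHK cells (Mesocricetus auratus) for cytotoxicity, read by MTT assay; a lower number here means that less compound is tolerated, a higher number that more compound is tolerated. Compound 1 `CC1CCCCC1N(CCCCCCN1C[C@H](O)[C@@H](O)[C@H](O)[C@H]1CO)C(=O)C(C)(C)C` carries a methyl on a saturated ring carbon and a tert-butyl on the carbonyl carbon. In this assay compound 1 gives > 500000 nM, which is a limit of the assay and not a number. Compound 2 `CC(C)(C)C(=O)N(CCCCCCN1C[C@H](O)[C@@H](O)[C@H](O)[C@H]1CO)C1CCCCC1` has hydrogen in place of that methyl. In this assay compound 2 gives > 500000 nM, again a limit rather than a number. Compound 3 `CC(=O)N(CCCCCCN1C[C@H](O)[C@@H](O)[C@H](O)[C@H]1CO)C1CCCCC1` has methyl in place of tert-butyl on the carbonyl carbon. In this assay compound 3 gives > 500000 nM, likewise only a limit. Compound 3 therefore stands at the limit, and the two other values shown sit there as well. The step that the two limits leave unreadable from compound 1 to compound 2 and the step that the two limits leave unreadable from compound 2 to compound 3 cannot be read in size, because of the limit of > 500000 nM in this assay, at which 3 of the 3 values shown sit. Compound 4 `CC(C)(C)CC(=O)N(CCCCCCN1C[C@H](O)[C@@H](O)[C@H](O)[C@H]1CO)C1CCCCC1` differs from compound 3 by tert-butyl in place of hydrogen on a saturated chain carbon bound to a carbonyl carbon. Among the compounds with values here, neither measured step says anything readable about this change, and every value so far stops at the limit. The expected step is a step that the limit leaves unreadable from compound 3 to compound 4, that is, none that can be resolved. Compound 4 is estimated at 600000 nM, within 200000 nM to 2000000 nM, and most likely it will again be reported only as a limit.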

Compound 4, half-maximal cytotoxic concentration: > 500000 nM
Compound 4 was reported as a limit (the forecaster's own chance of this, stated with the estimate: 85%); the middle value does not contradict the limit.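

Neither the step from compound 3 to compound 4 nor the step from compound 2 to compound 4 can be read in size, because each compound stands at a limit and not at a number: the limit of > 500000 nM in this assay, at which 4 of the 4 values shown sit.

The compounds shown leave open where each truly stands in this assay, and whether any of these changes shifts the value at all.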